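This account rests on a few compounds, and the source may have more. Where it says the series, first, only, none or still open, it means among the compounds named here.

Measured so far:
- compound 1, `C[C@@H](/N=C(\S)NCc1ccc(C(C)(C)C)cc1)c1ccc(C(C)(C)C)cc1`: 3490 nM
- compound 2, `CC(C)C(/N=C(\S)NCc1ccc(C(C)(C)C)cc1)c1ccc(NS(C)(=O)=O)cc1`: 3240 nM

In a functional assay for inhibition, with Rattus norvegicus as the target (a higher number here means a weaker inhibitor, a lower number a stronger inhibitor), compound 1 gives 3490 nM, the higher of the two numbers, while compound 2 gives 3240 nM; the two values lie within the scatter of each other, so no order can be read from them.

Compound 3, `CC(=O)Nc1ccc([C@@H](C)/N=C(\S)NCc2ccc(C(C)(C)C)cc2)cc1`, is not yet measured. It differs from compound 1 as acetamido in place of tert-butyl on an aromatic carbon. Among the compounds with values here, no step between measured compounds covers this change. Since compound 2 carries a different group at that ring and still gives 3240 nM, close to compound 1, the expected step of a 1.0-fold higher number from compound 1 to compound 3 (0.00 log units; within the scatter) is small, none beyond the scatter. Compound 3 is thus estimated at 3500 nM, in the range 1200 nM to 10000 nM.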

Compound 3, half-maximal inhibitory concentration: 3600 nM
Compound 3: middle estimate off by 1.0-fold (0.01 log units), on the low side; measured number inside the range.
By their numbers in this assay, from the lowest: compounds 2, 1 and 3 (each within the scatter of the next).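

In this assay, acetamido in place of tert-butyl on an aromatic carbon, para to a large group, gives a 1.0-fold higher number from compound 1 to compound 3 (0.01 log units; within the scatter) and so no readable change. At this position, a group with a hydrogen-bond donor and acceptor thus stands in for one with neither, at the same heavy-atom count, with the value staying within the scatter. Nothing measured here accounts for this result.

Only these two groups can be compared directly at this position. As far as these compounds go, whether a bare hydrogen, an amine or a carboxylic acid there would move the value remains open.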